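The source may hold more compounds than are shown below. What is called first, only, known or untested is meant among the compounds shown, and "the series" means these compounds.

Compound 1 (`CCNC(=O)c1noc(-c2cc(C(C)C)c(O)cc2O)c1-c1cc(COCC(=O)O)no1`) is the starting point of this step. For compound 1 the outcome in a functional assay on A2780 cells (Homo sapiens) for inhibition (a lower number here means a stronger inhibitor, a higher number a weaker inhibitor), is recorded only as "not determined" (no result reported), so no number anchors the start. Two related compounds do carry numbers: compound 2 (`CCNC(=O)c1noc(-c2cc(C(C)C)c(O)cc2O)c1-c1cc(CNC(C)C)no1`) gives 38 nM in this assay, and compound 3 (`CCNC(=O)c1noc(-c2cc(C(C)C)c(O)cc2O)c1-c1cc(CN(C)C)no1`) gives 31 nM; the step of a 1.2-fold lower number from compound 2 to compound 3 (0.09 log units; within the scatter) lies within the scatter. Compound 4 (`CCNC(=O)c1cc(-c2c(C(=O)NCC)noc2-c2cc(C(C)C)c(O)cc2O)on1`) differs from compound 1 as follows: ethylcarbamoyl in place of (carboxymethoxy)methyl on an aromatic carbon. Within the data shown here, none of the measured steps involves this change, so no direction beyond the scatter can be read from them. Taking the numbers of compound 2 and compound 3 as the only guide, compound 4 is expected to give about 60 nM in this assay, estimated between 15 nM and 250 nM.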

Compound 4, half-maximal inhibitory concentration: 43 nM
The estimate for compound 4 lay 1.4-fold (0.14 log units) above the measured number; measured number inside the range.
By their numbers in this assay, from the lowest: compounds 3, 2 and 4 (each within the scatter of the next).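

At this position of the shared core, the ethylcarbamoyl group of compound 4 matches both amine-bearing side chains in this assay. Replacing (dimethylamino)methyl gives (a 1.4-fold higher number from compound 3 to compound 4 (0.14 log units; within the scatter)) and replacing (isopropylamino)methyl gives (a 1.1-fold higher number from compound 2 to compound 4 (0.05 log units; within the scatter)), so across these three compounds the change of group leaves the number within the scatter. No evidence is available to explain this match.

Going by these compounds, the step from compound 1 cannot be read, so the effect of its (carboxymethoxy)methyl group stays unknown. On these data alone, whether a hydroxymethyl group or a longer amide such as butylcarbamoyl would fit here also stays open.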